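Swapping aminophenyl for fluorophenyl: expected tolerance in cells

The source may hold more compounds than are shown below. What is called first, only, known or untested is meant among the compounds shown, and "the series" means these compounds.

Compound 1 `CCOC(=O)c1cnc2ccc(-c3cccc(N)c3)cc2c1` gives > 7400 nM in a functional assay on RD cells (Homo sapiens) for inhibition, read by luminescence and ATP content, with a stated time of 72 h (a lower number here means that less compound is tolerated, a higher number that more compound is tolerated), a limit of the assay rather than a number.
Compound 2 `Cc1nc(-c2cnc3ccc(-c4ccccc4)cc3c2)no1` gives > 2500 nM in this assay, again a limit.
Compound 3 `CCc1nc(-c2cnc3ccc(-c4cccc(N)c4)cc3c2)no1` gives > 7400 nM in this assay, also a limit.

Compound 3 therefore sits at the higher of the two limits seen, (the limit of > 7400 nM in this assay, at which 2 of the 3 values shown sit), alongside compound 1, while compound 2 sits at the limit of > 2500 nM in this assay, at which 1 of the 3 values shown sits. For the measured compounds named here, the only measured step, a step that the two limits leave unreadable from compound 1 to compound 3, cannot be sized because both ends are limits. Compound 4 `CCc1nc(-c2cnc3ccc(-c4ccc(F)cc4)cc3c2)no1` differs from compound 3 by 4-fluorophenyl in place of 3-aminophenyl on an aromatic carbon. Going by the values given here, no measured step touches this change, so no direction beyond the scatter is expected. Compound 4 is estimated at 10000 nM in this assay, between 3000 nM and 30000 nM, and the expected step that the limit leaves unreadable from compound 3 to compound 4 means most likely another limit rather than a number.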

Compound 4, half-maximal cytotoxic concentration: > 7400 nM
Compound 4: no number, only a limit; the forecaster's own chance of this, stated with the estimate: 80%; the middle value does not contradict the limit.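

Compound 3 and compound 4 both give only a limit in this assay, not a number, so the step between them cannot be read. As far as these compounds go, whether 4-fluorophenyl and 3-aminophenyl differ in how well cells tolerate them remains open.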